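From Methoxy to Nitro: An Estimate for Compound 4

The source may report more compounds than this note shows. Statements on the series, on what has been measured and on what is new or still open speak of the compounds shown alone.

Measured in a functional assay on PANC-1 cells (Homo sapiens) for inhibition, read by MTT assay, with a stated time of 24 h, tested at 10 uM; on this read-out higher numbers stand for more inhibition at the one concentration tested (going by the name of the read-out) and lower numbers for less inhibition:
compound 1 `CC(C)=CCC/C(C)=C/CC1Cc2c(O)cc(=O)n(CCCO)c2CC1(C)C` gives 28.7%;
compound 2 `CCOc1cc(=O)n(CCCO)c2c1CC(CC=C(C)C)C(C)(C)C2` gives 66.5%;
compound 3 `COc1ccc(C(=O)NCCCOc2cc(=O)n(CCCO)c3c2CC(CC=C(C)C)C(C)(C)C3)cc1` gives 55.5%.

Compound 3 stands second highest of the three numbers; its nearest neighbour is compound 2, which lies higher beyond the scatter, and the furthest is compound 1, which lies lower beyond the scatter. Among the compounds with values here, the one measured step, a number 11 percentage points lower from compound 2 to compound 3 (beyond the scatter), concerns a different change and therefore does not directly bear on the move to compound 4 `CC(C)=CCC1Cc2c(OCCCNC(=O)c3ccc([N+](=O)[O-])cc3)cc(=O)n(CCCO)c2CC1(C)C`. That move is nitro in place of methoxy on an aromatic carbon. Within the data shown here, with no measured step on this change, the estimate for compound 4 is expected to stay near compound 3, at 55% with a range from 35% to 72%. The expected step is a number 0.5 percentage points lower from compound 3 to compound 4 (within the scatter), none beyond the scatter.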

Compound 4, a percentage reported as inhibition, at one concentration (the size of the read-out at that concentration, not a potency): 49.9%
Compound 4: middle estimate off by 5.1 percentage points, on the high side; measured number inside the range.
By their numbers in this assay, from the lowest: compound 1; then compounds 4 and 3 (each within the scatter of the next); then compound 2.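

In this assay nitro in place of methoxy on an aromatic carbon para to a large group gives a number 5.6 percentage points lower from compound 3 to compound 4 (within the scatter) and so, at this position, the two groups cannot be told apart on this read-out. The earlier compounds shown here did not vary this position and could not show this. Nothing available explains the result. On these data alone, whether an amine or a carboxylic acid at the same position would also stay within the scatter of compound 3 remains open. Two groups at one position also establish no trend for other groups there.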